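The source may report more compounds than this note shows. Statements on the series, on what has been measured and on what is new or still open speak of the compounds shown alone.

Measured in a functional assay on a cell-free system (Platelet, plasma, Homo sapiens) for inhibition; a higher number here means a weaker inhibitor, a lower number a stronger inhibitor:
Compound 1 `Cc1ccc(N(CCN2CCC(OCC(=O)O)CC2)C(=O)c2cccc(Cl)c2)cc1`: 100 nM
Compound 2 `O=C(O)COC1CCN(CCN(C(=O)c2ccc(C(F)(F)F)cc2)c2ccc(Cl)cc2)CC1`: > 10000 nM

For compound 2, the entry > 10000 nM is a limit of the assay and not a number.

Compound 3 `O=C(O)COC1CCN(CCN(C(=O)c2cccc(Cl)c2)c2ccc(Cl)cc2)CC1` has not been measured yet. It differs from compound 2 in one place: 3-chlorophenyl in place of 4-(trifluoromethyl)phenyl on a carbonyl carbon. Put simply, 3-chlorophenyl stands in place of 4-(trifluoromethyl)phenyl on a carbonyl carbon. For the measured compounds named here, no measured pair shows this exact change, so the expectation rests on a single comparison. Compound 1 carries the same 3-chlorophenyl on a carbonyl carbon and gives 100 nM, which points to a large expected drop in this assay, towards stronger inhibition. The estimated size of this change is an at least 50-fold lower number from compound 2 to compound 3 (1.69 log units; beyond the scatter). With so little to go on, the expected range is wide. The estimate for compound 3 is 200 nM, with an expected range of 30 nM to 2000 nM.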

Compound 3, half-maximal inhibitory concentration: 350 nM
Compound 3: the middle estimate sits 1.8-fold (0.24 log units) below what was measured; the measured number falls inside the stated range.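

In this assay, 3-chlorophenyl in place of 4-(trifluoromethyl)phenyl on a carbonyl carbon gives an at least 28-fold lower number from compound 2 to compound 3 (1.45 log units; beyond the scatter), so the group at this position has a strong influence on inhibition in these compounds. The entry for compound 2 is a limit of the assay and not a number, so this step gives only the smallest possible size of the change: the limit of > 10000 nM in this assay, at which 1 of the 3 values shown sits. Chloro in place of methyl on an aromatic carbon gives a 3.5-fold higher number from compound 1 to compound 3 (0.54 log units; beyond the scatter), a much smaller step than the one made at the carbonyl carbon.

Still open, as far as these compounds go, is whether the large step depends on the chosen group or on where it sits on its ring: a 3-(trifluoromethyl)phenyl or a 4-chlorophenyl on the same carbonyl carbon would separate the two. Also open, from the compounds shown here alone, is how a ring carrying a nitrile or an amine would behave there.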